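Swapping cyclohexyl for a halogenated phenyl on a cytotoxicity scaffold

A few compounds are considered here, and "the series" means these few. Any claim that something is new, unique, unknown or untested is made for them only; others in the source may bear on it.

Measured so far:
compound 1, `Fc1ccc(Cc2ccc3c(NCCCNCc4ccco4)ccnc3c2)c(Cl)c1`, 5730 nM
compound 2, `c1coc(CNCCCNc2ccnc3cc(CC4CCCCC4)ccc23)c1`, 1700 nM
compound 3, `COc1cccc(CNCCCNc2ccnc3cc(CC4CCCCC4)ccc23)c1O`, 970 nM

These three compounds share a core and were tested in an ADME assay on HepG2 cells (Homo sapiens) for cytotoxicity, read by luminescence, CellTiter-Glo and ATP content, with a stated time of 72 h; a lower number here means that less compound is needed, a higher number that more compound is needed for the effect. Compound 2 and compound 3 differ only in one group, and the difference is 2-hydroxy-3-methoxyphenyl in place of furan-2-yl on a saturated chain carbon bound to an amine nitrogen; the step of a 1.8-fold lower number from compound 2 to compound 3 (0.24 log units; within the scatter) is small. Compound 1 is made from compound 2 by a second change, (2-chloro-4-fluorophenyl in place of cyclohexyl on a saturated chain carbon bound to an aromatic carbon), and that step, a 3.4-fold higher number from compound 2 to compound 1 (0.53 log units; beyond the scatter), is larger.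

Compound 4, `COc1cccc(CNCCCNc2ccnc3cc(Cc4ccc(F)cc4Cl)ccc23)c1O`, has not yet been measured in this assay. It is made from compound 3 by 2-chloro-4-fluorophenyl in place of cyclohexyl on a saturated chain carbon bound to an aromatic carbon, which is the same change that turned compound 2 into compound 1, at the same place. The expectation therefore rests on that earlier step: starting from the value of compound 3, 970 nM, the step of a 3.4-fold higher number from compound 3 to compound 4 (0.53 log units; beyond the scatter) is expected to be of the same kind as a 3.4-fold higher number from compound 2 to compound 1 (0.53 log units; beyond the scatter). On that basis compound 4 is estimated at 3300 nM, with a likely range from 1500 nM to 7000 nM.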

Compound 4, half-maximal effective concentration: 2350 nM
Compound 4: the middle estimate sits 1.4-fold (0.15 log units) above what was measured; the measured number falls inside the stated range.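

In this assay, putting 2-chloro-4-fluorophenyl in place of cyclohexyl gives a 2.4-fold higher number from compound 3 to compound 4 (0.38 log units; beyond the scatter), a step in the same direction as the one seen earlier, and the two sizes agree: the same change on two cores in this assay, a 3.4-fold higher number (0.53 log units; beyond the scatter) from compound 2 to compound 1 and a 2.4-fold higher number (0.38 log units; beyond the scatter) from compound 3 to compound 4, 1.4-fold (0.14 log units) apart, within the scatter of two such steps. Among these compounds, the other change, 2-hydroxy-3-methoxyphenyl in place of furan-2-yl, gives a 2.4-fold lower number from compound 1 to compound 4 (0.39 log units; beyond the scatter), and although only this step lies beyond the scatter, it cannot be told apart from its earlier counterpart: the same change on two cores in this assay, a 1.8-fold lower number (0.24 log units; within the scatter) from compound 2 to compound 3 and a 2.4-fold lower number (0.39 log units; beyond the scatter) from compound 1 to compound 4, 1.4-fold (0.14 log units) apart, within the scatter of two such steps. So in these four compounds each change carried over from one core to the other, but each rests on just two pairs in a single cell assay, which shows neither that this would hold on further cores nor why the numbers move.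

The compounds shown leave open whether plain phenyl in place of cyclohexyl would give a step of similar size. From the compounds shown here alone, it also remains open whether the steps would keep their size with a longer chain carrying the amine, or with a carboxylic acid on the benzyl group.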